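Imidazoline anilines at the alpha-1D receptor: next ring swap

The source may report more compounds than this note shows. Statements on the series, on what has been measured and on what is new or still open speak of the compounds shown alone.

Compound 1, `Cc1nc(-c2ccccc2NCC2=NCCN2)co1`: in a functional assay for activation of Alpha-1D adrenergic receptor (Homo sapiens) (on this read-out lower numbers stand for an effect already at smaller amounts and higher numbers for an effect only at larger amounts of compound), compound 1 gives < 5020 nM, a limit of the assay.
Compound 2, `Cc1noc(-c2ccccc2NCC2=NCCN2)n1`: in this assay compound 2 gives < 5020 nM, again a limit.
Compound 3, `c1ccc(-c2cnccn2)c(NCC2=NCCN2)c1`: in this assay compound 3 gives 182 nM.

Among the compounds with values here, compound 3 thus stands as the only numeric value in the set; the other two sit at the limit of < 5020 nM in this assay, at which 2 of the 3 values shown sit. The steps a step that the two limits leave unreadable from compound 1 to compound 2, a step that the limit leaves unreadable from compound 1 to compound 3 and a step that the limit leaves unreadable from compound 2 to compound 3 cannot be sized, so nothing measured bears directly on the next change.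

Compound 4, `c1cnc(-c2ccccc2NCC2=NCCN2)nc1`, differs from compound 3 by pyrimidin-2-yl in place of pyrazin-2-yl on an aromatic carbon. With no readable step to lean on, the expected step of a 1.6-fold higher number from compound 3 to compound 4 (0.22 log units; within the scatter) is taken as none beyond the scatter. Compound 4 is estimated at 300 nM, within 60 nM to 1500 nM.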

Compound 4, half-maximal effective concentration: 81.3 nM
Compound 4: middle estimate off by 3.7-fold (0.57 log units), on the high side; low and high end bracket the measured number.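

In this assay, within the data shown here, pyrimidin-2-yl in place of pyrazin-2-yl on an aromatic carbon gives a 2.2-fold lower number from compound 3 to compound 4 (0.35 log units; beyond the scatter), the first readable step. The two groups have the same atoms joined differently and the same counts of hetero atoms, donors and acceptors, so the arrangement of atoms within the ring alone moves the read-out at this position. The steps from compound 1 and compound 2 to compound 4 cannot be read: the limit of < 5020 nM in this assay, at which 2 of the 4 values shown sit.

Still open, on these data alone, is what a phenyl or pyridin-2-yl group would give at this position. Also open, as far as these compounds go, is whether an amine on the pyrimidin-2-yl ring would keep the number of compound 4.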